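Ethylthio analogue with a fluoro-methoxyphenyl group

The source may report more compounds than this note shows. Statements on the series, on what has been measured and on what is new or still open speak of the compounds shown alone.

The two measured compounds share a core and differ in several places at once. Compound 1 `COc1cc([C@](O)(CCN(C)C)[C@@H](c2cc3cc(Br)ccc3nc2OC)c2cccc(OC)c2F)cc(SC)n1` is measured in an ADME assay on microsomes from liver (Mus musculus) for metabolic stability (a higher number here means faster removal of the compound, a lower number slower removal), and gives 20 uL/min. Compound 2 `CCSc1cc([C@](O)(CCN(C)C)[C@H](c2ccccc2)c2cc3cc(Br)ccc3nc2OC)cc(SCC)n1` gives 17 uL/min in this assay, and its number and that of compound 1 lie within the usual scatter of each other, so neither stands apart from the other.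

Compound 3 `CCSc1cc([C@](O)(CCN(C)C)[C@@H](c2cc3cc(Br)ccc3nc2OC)c2cccc(OC)c2F)cc(SCC)n1` has not yet been measured in this assay. It differs from compound 2 in one place: 2-fluoro-3-methoxyphenyl in place of phenyl on a saturated chain carbon bound to an aromatic carbon and a saturated chain carbon. The same 2-fluoro-3-methoxyphenyl group is present in compound 1, whose value of 20 uL/min sits close to that of compound 2.

No step between measured compounds exists that isolates this change, so what is expected for compound 3 rests on the two numbers shown. Compound 3 is expected to give about 20 uL/min in this assay, with a range from 10 uL/min to 40 uL/min. The step that this estimate means, a 1.2-fold higher number from compound 2 to compound 3 (0.07 log units; within the scatter), is expected to be none beyond the scatter.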

Compound 3, intrinsic clearance in a liver preparation (reported as CLH), per the amount of preparation that the assay uses: 12 uL/min
For compound 3 the middle estimate is 1.7-fold (0.22 log units) above the measured one; the range from low to high includes it.
By their numbers in this assay, from the lowest: compounds 3, 2 and 1 (each within the scatter of the next).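

In this assay, within the data shown here, 2-fluoro-3-methoxyphenyl in place of phenyl on a saturated chain carbon bound to an aromatic carbon and a saturated chain carbon gives a 1.4-fold lower number from compound 2 to compound 3 (0.15 log units; within the scatter) and so provides the first direct reading of this change, which does not move the number beyond the scatter. The group on a saturated chain carbon bound to an oxygen on a saturated carbon and two saturated chain carbons can now be read as well: the group of 12 heavy atoms in place of the group of 10 heavy atoms gives a 1.7-fold lower number from compound 1 to compound 3 (0.22 log units; within the scatter) and also stays inside the scatter, with 2-fluoro-3-methoxyphenyl present on both sides of the step. Nothing measured here speaks to what lies behind either step.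

Every step shown stays within the scatter, so it remains open whether any change at these two places can separate compounds in this assay at all. From the compounds shown here alone, an amine, a carboxylic acid or a longer chain in place of phenyl could answer this for the first position, while the effect of the same changes on the shared core remains unknown.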